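Three Amides Level on Potency, One Untested Change

The source may report more compounds than this note shows. Statements on the series, on what has been measured and on what is new or still open speak of the compounds shown alone.

compound 1 `CCn1c(C(=O)NCCN(C)C)ccc1C(CC)(CC)c1ccc(OCCC(O)(CC)CC)c(C)c1` gives 1140 nM
compound 2 `CCN(CC)CCNC(=O)c1ccc(C(CC)(CC)c2ccc(OCCC(O)(CC)CC)c(C)c2)n1CC` gives 1630 nM
compound 3 `CCn1c(C(=O)NCCN)ccc1C(CC)(CC)c1ccc(OCCC(O)(CC)CC)c(C)c1` gives 1740 nM

In a functional assay on Caco-2 cells (Homo sapiens) for antiproliferative activity, read by MTT assay, with a stated time of 48 h (on this read-out lower numbers stand for stronger inhibition and higher numbers for weaker inhibition), compound 3 stands within the scatter of both other compounds. The change to compound 4 `C=CCN(C)C(=O)c1ccc(C(CC)(CC)c2ccc(OCCC(O)(CC)CC)c(C)c2)n1CC` is allyl(methyl)amino in place of (2-aminoethyl)amino on a carbonyl carbon, which means allyl(methyl)amino in place of (2-aminoethyl)amino on a carbonyl carbon. The nearest evidence is a 1.4-fold higher number from compound 1 to compound 2 (0.16 log units; within the scatter), a 1.5-fold higher number from compound 1 to compound 3 (0.18 log units; within the scatter) and a 1.1-fold higher number from compound 2 to compound 3 (0.03 log units; within the scatter), all within the scatter. These steps only exchange amino, dimethylamino and diethylamino on a saturated chain carbon, so they guide this larger change loosely. No step beyond the scatter is expected, and the estimate is a 1.1-fold higher number from compound 3 to compound 4 (0.06 log units; within the scatter). Compound 4 is estimated at 2000 nM, with an expected range from 650 nM to 6500 nM.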

Compound 4, half-maximal inhibitory concentration: > 50000 nM
Compound 4: a limit, no number; the forecaster's own chance of this, stated with the estimate: 10%; middle value at least 25-fold (1.39 log units) from the limit.
By their numbers in this assay, from the lowest: compounds 1, 2 and 3 (each within the scatter of the next). At a limit, above all of these: compound 4.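

The earlier steps shown here only exchanged groups on the end of the side chain and stayed within the scatter, but replacing the whole group on the carbonyl carbon matters greatly in this assay, with an at least 28-fold higher number from compound 3 to compound 4 (1.45 log units; beyond the scatter). The other two amides give the same picture, with an at least 30-fold higher number from compound 2 to compound 4 (1.48 log units; beyond the scatter) and an at least 43-fold higher number from compound 1 to compound 4 (1.64 log units; beyond the scatter). Compound 4 has a limit rather than a number: the limit of > 50000 nM in this assay, at which 1 of the 4 values shown sits.

Which part of the change carries this loss remains open: the amine of the chain, the amide hydrogen or the allyl group. Allylamino or (2-aminoethyl)(methyl)amino on the same carbonyl carbon would help separate these.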